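Swapping 3-hydroxypropyl for 2-hydroxycyclohexyl on a weak compound

A few compounds are considered here, and "the series" means these few. Any claim that something is new, unique, unknown or untested is made for them only; others in the source may bear on it.

In a functional assay on PC-3M cells (Homo sapiens) for antiproliferative activity, read by microscopy, with a stated time of 24 h (on this read-out higher numbers stand for weaker inhibition and lower numbers for stronger inhibition), compound 1 (`N=c1c2c(-c3ccccc3)c(-c3ccccc3)n(CC3CCCCC3)c2ncn1CCCO`) gives 27700 nM; 26900 nM (2 entries) across its repeat entries. Compound 3 (`COc1ccc(Cn2c(-c3ccccc3)c(-c3ccccc3)c3c(=N)n(CCCO)cnc32)cc1`) gives 2170 nM; 2140 nM (2 entries) on the same read-out, a lower number than compound 1 shows. Compound 2 (`COc1ccc(-c2c(-c3ccc(OC)cc3)n(Cc3ccccc3)c3ncn(CCCO)c(=N)c23)cc1`) stands at > 20000 nM as a limit of the assay and not a number, and its two further entries carry no single number either.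

Compound 4 (`COc1ccc(-c2c(-c3ccc(OC)cc3)n(Cc3ccccc3)c3ncn([C@@H]4CCCC[C@H]4O)c(=N)c23)cc1`) keeps the rest of compound 2 and carries 2-hydroxycyclohexyl in place of 3-hydroxypropyl on an aromatic nitrogen, a change counted as 2-hydroxycyclohexyl in place of 3-hydroxypropyl on an aromatic nitrogen in full. The entering group brings a six-membered non-aromatic ring of carbon only. For the measured compounds named here, all three measured compounds carry 3-hydroxypropyl at this place, so no measured pair shows what a change there does in this assay on its own.

A small step towards stronger inhibition is expected, possibly none beyond the scatter. Going by the values given here, the only hint is compound 3, whose 2170 nM; 2140 nM (2 entries) shows that much lower numbers occur. The estimated move is an at least 1.4-fold lower number from compound 2 to compound 4 (0.15 log units; that floor lies within the scatter) on this reading. For compound 4 the expected value is 14000 nM with an estimated range from 4500 nM to 40000 nM and a real chance of only a limit.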

Compound 4, half-maximal inhibitory concentration: > 20000 nM
Compound 4: a limit, no number; the forecaster's own chance of this, stated with the estimate: 45%; middle value at least 1.4-fold (0.15 log units) away from the limit.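

In this assay, compound 4 and compound 2 both give only a limit of the assay and not a number, so the step between them cannot be read. The compounds shown leave open whether 2-hydroxycyclohexyl in place of 3-hydroxypropyl on an aromatic nitrogen changes inhibition at all, in either direction.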